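A few compounds are considered here, and "the series" means these few. Any claim that something is new, unique, unknown or untested is made for them only; others in the source may bear on it.

Compounds measured so far:
compound 1, `O=S(=O)(Nc1ccc(-c2nc3ccccc3o2)cc1)c1cccc(O)c1`, > 63000 nM
compound 2, `O=S(=O)(Nc1ccc2oc(-c3ccccc3)nc2c1)c1ccc(Cl)c(C(F)(F)F)c1`, > 63000 nM

Both values come from an assay on isolated protein for inhibition of malate dehydrogenase, mitochondrial (Sus scrofa), with stated times of 45 min and 30 min; a higher number here means a weaker inhibitor, a lower number a stronger inhibitor. For compound 1 the value is a limit of this assay and not a number. For compound 2 the value is likewise a limit of this assay. For the measured compounds named here, compound 1 thus stands at the limit of > 63000 nM in this assay, at which 2 of the 2 values shown sit; no numbered value exists, and no step between measured compounds can be counted.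

Compound 3, `COc1cccc(S(=O)(=O)Nc2ccc(-c3nc4ccccc4o3)cc2)c1`, has not yet been measured. It differs from compound 1 by methyl in place of hydrogen on an oxygen on an aromatic ring. Since compound 1 sits at the limit, the change in this assay is expected to be small, most likely none beyond the scatter, and the result for compound 3 is expected to remain a limit. The estimate for compound 3 is 100000 nM, with a range of 30000 nM to 400000 nM. This estimate means an expected step that the limit leaves unreadable from compound 1 to compound 3.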

Compound 3, half-maximal inhibitory concentration: > 63000 nM
Compound 3: no number, only a limit; the forecaster's own chance of this, stated with the estimate: 85%; the middle value does not contradict the limit.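

The step from compound 1 to compound 3 cannot be read, as both values are limits and not numbers in this assay: the limit of > 63000 nM in this assay, at which 3 of the 3 values shown sit. The compounds shown leave open whether 3-hydroxyphenyl and 3-methoxyphenyl differ at all in this assay, and which structure would give a numbered value.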